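This account rests on a few compounds, and the source may have more. Where it says the series, first, only, none or still open, it means among the compounds named here.

Compound 1 `O=C1N=C(N2CCC[C@H]2C(=O)Nc2ccc3ncnc(Nc4cccc(Cl)c4)c3c2)S/C1=C/c1ccccc1Cl`: > 50000 nM (a limit)
Compound 2 `O=C1N=C(N2CCC[C@H]2C(=O)Nc2ccc3ncnc(Nc4cccc(Cl)c4)c3c2)S/C1=C/c1cccc(Br)n1`: 3100 nM

Among the compounds with values here, in a functional assay on A549 cells (Homo sapiens) for antiproliferative activity, read by MTT assay (a higher number here means a weaker inhibitor, a lower number a stronger inhibitor), compound 2 gives 3100 nM, the only true number so far. Compound 1 gives > 50000 nM, which is a limit of the assay and not a number. Within the data shown here, the one measured step is an at least 16-fold lower number from compound 1 to compound 2 (1.20 log units; beyond the scatter). It shows that the group at this place can shift the result strongly.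

Compound 3 `O=C1N=C(N2CCC[C@H]2C(=O)Nc2ccc3ncnc(Nc4cccc(Cl)c4)c3c2)S/C1=C/c1cccnc1Cl` changes the same place: 2-chloropyridin-3-yl in place of 6-bromopyridin-2-yl on a double-bonded chain carbon bound to a double-bonded ring carbon. The entering 2-chloropyridin-3-yl keeps a ring with a hetero atom, as in compound 2, but its chlorine recalls the 2-chlorophenyl of compound 1. A moderately higher number is therefore expected, given the large at least 16-fold lower number from compound 1 to compound 2 (1.20 log units; beyond the scatter), and a result at the limit remains possible. The expected change is a 2.9-fold higher number from compound 2 to compound 3 (0.46 log units; beyond the scatter). For compound 3 the estimate is 9000 nM, with an expected range from 2500 nM to 40000 nM.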

Compound 3, half-maximal inhibitory concentration: 10800 nM
The estimate for compound 3 lay 1.2-fold (0.08 log units) below the measured number; the range from low to high includes it.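

Two pyridine rings with the same counts of heavy atoms, donors and acceptors are not interchangeable at this place in this assay: replacing 6-bromopyridin-2-yl with 2-chloropyridin-3-yl gives a 3.5-fold higher number from compound 2 to compound 3 (0.54 log units; beyond the scatter). Placing 2-chloropyridin-3-yl instead of 2-chlorophenyl gives an at least 4.6-fold lower number from compound 1 to compound 3 (0.66 log units; beyond the scatter), so among these three compounds, both rings with a hetero atom give lower numbers than the phenyl ring. The true size of that step is unknown, since the value for compound 1 is a limit and not a number: the limit of > 50000 nM in this assay, at which 1 of the 3 values shown sits.

The two pyridine groups differ in both their halogen and their ring attachment, so these compounds cannot separate the two changes. Going by these compounds, whether a pyridine ring bearing an amine, or one with no halogen, would match compound 2 also remains open.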